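From Compound 2 to Compound 3: Adding a Methoxy Group

The source may hold more compounds than are shown below. What is called first, only, known or untested is meant among the compounds shown, and "the series" means these compounds.

In a functional assay on PC-3 cells (Homo sapiens) for cytotoxicity, read by MTT assay, with a stated time of 72 h (a higher number here means a weaker inhibitor, a lower number a stronger inhibitor), compound 1 `Nc1ccc(Nc2nc3ccccc3nc2S(=O)(=O)c2ccccc2)cc1` gives 5830 nM and compound 2 `O=S(=O)(c1ccccc1)c1nc2ccccc2nc1Nc1ccc(Cl)cc1` gives 15300 nM, so compound 2 holds the higher number of the two and is the weaker inhibitor. Compound 3 `COc1ccc(S(=O)(=O)c2nc3ccccc3nc2Nc2ccc(Cl)cc2)cc1` matches compound 2 except for one change: methoxy in place of hydrogen on an aromatic carbon, para to a large group (methoxy in place of hydrogen on an aromatic carbon). For the measured compounds named here, the only measured step, a 2.6-fold higher number from compound 1 to compound 2 (0.42 log units; beyond the scatter), is modest. It concerns chloro in place of amino, a different change elsewhere in the molecule, so it sets a rough scale but no direction. On that scale, a small move in this assay is expected, perhaps none beyond the scatter. The estimated shift is a 1.2-fold lower number from compound 2 to compound 3 (0.07 log units; within the scatter). For compound 3 the expected value is 13000 nM, with an estimated range of 5000 nM to 33000 nM.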

Compound 3, half-maximal inhibitory concentration: 31800 nM
Compound 3: the middle estimate sits 2.4-fold (0.39 log units) below what was measured; low and high end bracket the measured number.
By their numbers in this assay, from the lowest: compound 1; then compound 2; then compound 3.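

In this assay, the change from phenyl to 4-methoxyphenyl gives a 2.1-fold higher number from compound 2 to compound 3 (0.32 log units; beyond the scatter) and so moves toward a weaker inhibitor. For the compounds shown here, the earlier pair changed a different part of the molecule, so this is the first sign that the ring carrying the new methoxy also responds to substitution, with a modest shift beyond the scatter. Nothing available explains why the number rises at this position.

The compounds shown leave open how an amine, a hydroxyl group or a carboxylic acid would behave in this same place on the ring. They also leave open whether methoxy would shift the number in the same direction on compound 1, which carries amino where compound 2 carries chloro.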